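A Trimethoxyphenyl Swap in a Level Cytotoxicity Series

The compounds below may be only part of what the source reports. "The series", "measured", "known", "first", "only" and "open" are said of these compounds alone.

Of the compounds shown here, three that share one core have been tested in a functional assay on HepG2 cells (Homo sapiens) for cytotoxicity, read by MTT assay, with a stated time of 72 h; on this read-out lower numbers stand for stronger inhibition and higher numbers for weaker inhibition. In this test, compound 1 `COc1cc2ncnc(Nc3ccc(F)c(Cl)c3)c2cc1NC(=O)N/N=C/c1ccc(C#N)cc1` gives 34100 nM, compound 2 `COc1cc2ncnc(Nc3ccc(F)c(Cl)c3)c2cc1NC(=O)N/N=C/c1ccc([N+](=O)[O-])cc1` gives 34100 nM, and compound 3 `COc1cc2ncnc(Nc3ccc(F)c(Cl)c3)c2cc1NC(=O)N/N=C/c1cccc(Cl)c1Cl` gives 26100 nM. All three numbers lie within the usual scatter of repeated measurements, so compound 3 stands level with the other two.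

The next structure, compound 4 `COc1cc2ncnc(Nc3ccc(F)c(Cl)c3)c2cc1NC(=O)N/N=C/c1ccc(OC)c(OC)c1OC`, carries 2,3,4-trimethoxyphenyl in place of 2,3-dichlorophenyl on a carbon with a double bond to nitrogen.

The most relevant evidence comes from two earlier swaps of the group at this same place. These were a 1.3-fold lower number from compound 1 to compound 3 (0.12 log units; within the scatter) and a 1.3-fold lower number from compound 2 to compound 3 (0.12 log units; within the scatter), and both stayed within the scatter. The smaller change of no change at the digits printed from compound 1 to compound 2 (within the scatter) also stayed within it. None of the three tested compounds carries a methoxy group, so this expectation remains uncertain.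

The expected result is a 1.1-fold higher number from compound 3 to compound 4 (0.03 log units; within the scatter), with no shift beyond the scatter in either direction. In this assay, compound 4 is estimated at 28000 nM, with an expected range from 12000 nM to 60000 nM.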

Compound 4, half-maximal inhibitory concentration: 31200 nM
Beside the measured number, compound 4's estimate is 1.1-fold (0.05 log units) below it; the range from low to high includes it.
By their numbers in this assay, from the lowest: compounds 3, 4, 1 and 2 (each within the scatter of the next).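

In this assay, placing 2,3,4-trimethoxyphenyl on this carbon with a double bond to nitrogen gives a 1.2-fold higher number from compound 3 to compound 4 (0.08 log units; within the scatter) when it replaces 2,3-dichlorophenyl. It also gives a 1.1-fold lower number from compound 2 to compound 4 (0.04 log units; within the scatter) when it replaces 4-nitrophenyl and a 1.1-fold lower number from compound 1 to compound 4 (0.04 log units; within the scatter) when it replaces 4-cyanophenyl, and all three steps stay within the scatter. So a group with methoxy substituents and hydrogen-bond acceptors, which 2,3-dichlorophenyl lacks, still leaves the result level with the other compounds, and no outside measurement is available to help explain this result.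

All four compounds carry a substituted phenyl ring at this place, so this level result says nothing yet about other kinds of group. As far as these compounds go, it remains open whether a phenyl ring bearing an amine or a carboxylic acid, or a longer chain in place of the ring, would give a step beyond the scatter.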